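This account rests on a few compounds, and the source may have more. Where it says the series, first, only, none or still open, it means among the compounds named here.

Measured so far in a functional assay on DU-145 cells (Homo sapiens) for inhibition; a higher number here means a weaker inhibitor, a lower number a stronger inhibitor:
- compound 1 `Oc1ccc(-c2cc(-c3cccc(F)c3)cc(-c3ccc(O)cc3)n2)cc1` gives 9290 nM.
- compound 2 `Oc1ccc(-c2cc(-c3ccccc3C(F)(F)F)cc(-c3ccccc3O)n2)cc1` gives 6690 nM.
- compound 3 `Oc1ccc(-c2cc(-c3ccc(C(F)(F)F)cc3)cc(-c3ccccc3O)n2)cc1` gives only the assay limit > 50000 nM, not a number.

Compound 2 has the lowest of the two numbers; compound 1 sits within the scatter of it. Within the data shown here, the one measured step, an at least 7.4-fold higher number from compound 2 to compound 3 (0.87 log units; beyond the scatter), concerns the trifluoromethyl position and ends at a limit (the limit of > 50000 nM in this assay, at which 1 of the 3 values shown sits).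

Compound 4 `Oc1ccc(-c2cc(-c3ccccc3C(F)(F)F)cc(-c3ccc(O)cc3)n2)cc1` differs from compound 2 by 4-hydroxyphenyl in place of 2-hydroxyphenyl on an aromatic carbon. Among the measured compounds shown here, no measured step touches the hydroxy position, so the size of the effect in this assay is unknown; the expectation is a step near zero, within the scatter, a 1.0-fold higher number from compound 2 to compound 4 (0.02 log units; within the scatter). Compound 4 is estimated at 7000 nM, range 2500 nM to 20000 nM.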

Compound 4, half-maximal inhibitory concentration: > 50000 nM
Compound 4: a limit, no number (the forecaster's own chance of this, stated with the estimate: 10%); middle value at least 7.1-fold (0.85 log units) from the limit.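

Hydroxy placement is not neutral here: with the same atoms joined differently, 4-hydroxyphenyl in place of 2-hydroxyphenyl gives an at least 7.4-fold higher number from compound 2 to compound 4 (0.87 log units; beyond the scatter). With 4-hydroxyphenyl kept, 2-(trifluoromethyl)phenyl in place of 3-fluorophenyl gives an at least 5.3-fold higher number from compound 1 to compound 4 (0.73 log units; beyond the scatter), so among the compounds shown, 2-(trifluoromethyl)phenyl keeps a number in this assay only in compound 2, which carries 2-hydroxyphenyl. Compound 4 gives > 50000 nM, a limit of the assay and not a number.

Open, on these data alone, is the true size of both steps. Also open, as far as these compounds go, is whether an amine or a methoxy group can replace the hydroxy of 2-hydroxyphenyl and still give a number.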